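Working notes: cyclopentyl to cyclopropyl on the chain carbon

The source may hold more compounds than are shown below. What is called first, only, known or untested is meant among the compounds shown, and "the series" means these compounds.

Measured compounds:
compound 1 `FC(F)(F)c1ccc(-c2ccc(Cn3nnc4ccccc43)cc2)c(Cl)c1` — 0.5 mL/min/g
compound 2 `Brc1ccc(Cn2nnc3c(Br)cccc32)cn1` — "not determined" (no result reported)
compound 3 `Brc1cccc2c1nnn2CC1CCCC1` — 14.6 mL/min/g

Three compounds have been through an ADME assay on microsomes from liver (Rattus norvegicus, strain Wistar) for metabolic stability, tested at 2.5 uM; a higher number here means faster removal of the compound, a lower number slower removal. Going by the values given here, compound 2 has no result there, so only two numbers are available. Of these, compound 3 stands highest; the nearest number, that of compound 1, lies far below it, and the gap between compound 1 and compound 3 is well beyond the scatter of this assay. Nothing connects compound 1 and compound 3 by a single change, so the two values are only taken as they stand.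

The next compound, compound 4 `Brc1cccc2c1nnn2CC1CC1`, differs from compound 3 in one place: cyclopropyl in place of cyclopentyl on a saturated chain carbon bound to an aromatic nitrogen.

Among the compounds with values here, no step between two measured compounds covers this change, so the expected size rests on judgement alone. A fall in this assay, beyond the scatter but not large, is expected from compound 3 to compound 4. Given the high starting point of compound 3 at 14.6 mL/min/g, the expected step of a 2.4-fold lower number from compound 3 to compound 4 (0.39 log units; beyond the scatter) is a moderate drop. Compound 4 is expected to give 6 mL/min/g, with a range from 2 mL/min/g to 15 mL/min/g.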

Compound 4, intrinsic clearance in a liver preparation (reported as CLH), per the amount of preparation that the assay uses: 0.6 mL/min/g
Compound 4: the middle estimate sits 10-fold (1.00 log units) above what was measured; measured number below the stated range.
By their numbers in this assay, from the lowest: compounds 1 and 4 (each within the scatter of the next); then compound 3.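

In this assay, the saturated chain carbon bound to an aromatic nitrogen proves to be a position where a single change moves the read-out strongly: cyclopropyl in place of cyclopentyl gives a 24-fold lower number from compound 3 to compound 4 (1.39 log units; beyond the scatter). Going by these compounds alone, this is the first step that isolates one change, and the earlier compounds gave no measure of how much this position can shift the number. Nothing at hand accounts for the size of the step.

Going by these compounds, whether the number falls gradually with ring size or abruptly at the three-membered ring stays open, and a cyclobutyl group or an open isopropyl chain on the same carbon would be the informative comparison. Within the data shown here, also open is whether a step of this size holds on another core, as the change is seen in only one pair.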